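This account rests on a few compounds, and the source may have more. Where it says the series, first, only, none or still open, it means among the compounds named here.

In a functional assay on PC-3 cells (Homo sapiens) for antiproliferative activity, with a stated time of 48 h (on this read-out higher numbers stand for weaker inhibition and lower numbers for stronger inhibition), compound 1 (`CCN(CC)c1ccc(-c2cccc(OC)c2)nn1`) gives > 25000 nM as a limit and not a number. Compound 2 (`COC(=O)c1cccc(-c2ccc(-n3cccc3)nn2)c1`) gives > 25000 nM as a limit too. Compound 3 (`COc1ccc(Nc2ccc(-c3ccccc3)nn2)cc1`) gives > 25000 nM as a limit too. Compound 1 therefore cannot be ranked against the other two, as no exact value is available for any of them.

Compound 4 (`CCN(CC)c1ccc(-c2cccc(Cl)c2)nn1`) keeps the core of compound 1 and carries chloro in place of methoxy on an aromatic carbon, meta to a large group (chloro in place of methoxy on an aromatic carbon). For the measured compounds named here, no measured pair isolates a single change, so the size of this one has no direct precedent.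

Due to the limit of > 25000 nM in this assay, at which 3 of the 3 values shown sit, no change beyond the scatter is expected in this assay and any exact value would be expected on the side of stronger inhibition. The expected step of a number no higher from compound 1 to compound 4 (the limit leaves the size open) is small. For compound 4 the estimate is 25000 nM (expected range 10000 nM to 50000 nM).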

Compound 4, half-maximal inhibitory concentration: > 25000 nM
Compound 4 gave a limit, no number; the forecaster's own chance of this, stated with the estimate: 70%; the middle value sits exactly at the limit.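

In this assay compound 4 gives > 25000 nM, a limit and not a number. For the compounds shown here, no step between compound 1 and compound 4 can be read, since both are limits. The compounds shown leave open how large the effect of chloro in place of methoxy is, and whether any compound in this series gives an exact value in this assay.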